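Replacing diethylamino with chloro in the series

The source may report more compounds than this note shows. Statements on the series, on what has been measured and on what is new or still open speak of the compounds shown alone.

For the measured compounds named here, in a functional assay on A549 cells (Homo sapiens) for cytotoxicity, read by CCK-8 assay (on this read-out higher numbers stand for weaker inhibition and lower numbers for stronger inhibition), compound 1 (`O=C(Nc1ccc(O)cc1)c1ncc(-c2ccccc2)o1`) gives 1080 nM, the only reading so far that is a number. Compound 2 (`O=C(Nc1cccc(O)c1)c1ncc(-c2ccccc2)o1`) reads > 30000 nM, which is a limit. Compound 3 (`CCN(CC)c1ccc(NC(=O)c2ncc(-c3ccccc3)o2)cc1`) reads > 30000 nM, which is also a limit, so the step from it starts without a number.

Compound 4 (`O=C(Nc1ccc(Cl)cc1)c1ncc(-c2ccccc2)o1`) carries chloro in place of diethylamino on an aromatic carbon, para to a large group (chloro in place of diethylamino on an aromatic carbon).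

The closest measured step is an at least 27-fold higher number from compound 1 to compound 3 (1.44 log units; beyond the scatter), with diethylamino in place of hydroxy on that same aromatic carbon. Less directly relevant is an at least 27-fold higher number from compound 1 to compound 2 (1.44 log units; beyond the scatter), with 3-hydroxyphenyl in place of 4-hydroxyphenyl. On these data alone, both steps are large, and both end at the limit of > 30000 nM in this assay, at which 2 of the 3 values shown sit, so their true sizes remain open. Going by the values given here, no measured compound yet carries chloro. Among the compounds with values here, removing diethylamino is expected to lower the number, as the only numerical reading comes from compound 1 at 1080 nM, which lacks that group. A return all the way to that level is not assumed, and compound 4 may itself stay at the limit.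

The estimated step is an at least 5.0-fold lower number from compound 3 to compound 4 (0.69 log units; beyond the scatter). For compound 4 the expected value is 6000 nM, with an estimated range of 1200 nM to 30000 nM.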

Compound 4, half-maximal inhibitory concentration: > 30000 nM
Compound 4: a limit, no number; the forecaster's own chance of this, stated with the estimate: 30%; middle value at least 5.0-fold (0.69 log units) away from the limit.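

In this assay compound 4 reads > 30000 nM, which is a limit. Chloro in place of hydroxy on this aromatic carbon gives an at least 27-fold higher number from compound 1 to compound 4 (1.44 log units; beyond the scatter), so diethylamino is no longer the only replacement of the hydroxy group that loses the numerical reading, and among the compounds shown, only compound 1, with hydroxy on this carbon, keeps a number, while compound 2 shows that a hydroxy group alone does not ensure one when it sits on the 3-hydroxyphenyl. The steps from compound 3 and from compound 2 to compound 4 cannot be read, because both ends of each are limits: the limit of > 30000 nM in this assay, at which 3 of the 4 values shown sit.

On these data alone, how far compound 2, compound 3 and compound 4 lie beyond that limit stays open, so these three cannot be ranked against one another. Also open, as far as these compounds go, is whether a primary amine, a methoxy group or a carboxylic acid on this aromatic carbon would restore a numerical reading, which would show whether the response depends on the hydroxy group itself or tolerates other groups at this place.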